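Halogen swap at the para position in the thiosemicarbazone series

The source may hold more compounds than are shown below. What is called first, only, known or untested is meant among the compounds shown, and "the series" means these compounds.

Three compounds have numbers in a functional assay on MCF7 cells (Homo sapiens) for cytotoxicity, read by MTT assay, with a stated time of 48 h; on this read-out lower numbers stand for stronger inhibition and higher numbers for weaker inhibition. Compound 1 `C/C(=N\NC(=S)Nc1cccc(I)c1)c1ccccn1` gives 45 nM, compound 2 `CC(=NNC(=S)Nc1ccc(I)cc1)c1ccccn1` gives 6.6 nM, and compound 3 `C/C(=N\NC(=S)Nc1ccccc1Cl)c1ccccn1` gives 0.16 nM. Compound 2 thus stands second highest of the three, with compound 1 a higher number beyond the scatter and compound 3 far lower, also beyond the scatter.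

Compound 4 `CC(=NNC(=S)Nc1ccc(F)cc1)c1ccccn1` differs from compound 2 in one place: fluoro in place of iodo on an aromatic carbon. For the measured compounds named here, no measured pair shows this change, so its size is unknown. A modest rise in the number is expected for compound 4, with the step from compound 2 to compound 4 estimated as a 2.3-fold higher number from compound 2 to compound 4 (0.36 log units; beyond the scatter), though it could fall within the scatter. Compound 4 is expected to give 15 nM in this assay, in the range 3 nM to 70 nM.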

Compound 4, half-maximal inhibitory concentration: 1.2 nM
Compound 4: the middle estimate sits 13-fold (1.10 log units) above what was measured, and the stated range ends above it.
By their numbers in this assay, from the lowest: compound 3; then compound 4; then compound 2; then compound 1.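

In this assay, for the compounds shown here, fluoro in place of iodo on an aromatic carbon, para to a large group, gives a 5.5-fold lower number from compound 2 to compound 4 (0.74 log units; beyond the scatter), the first single-change step. The identity of the halogen at this place therefore moves the number beyond the scatter, and iodo is not required for a low number here. Nothing at hand bears on why the step has this size. Open, on these data alone, is how chloro, bromo, an amine or a carboxylic acid would read at this place. Also open, as far as these compounds go, is whether fluoro in place of iodo gives a similar step elsewhere on this ring.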